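A few compounds are considered here, and "the series" means these few. Any claim that something is new, unique, unknown or untested is made for them only; others in the source may bear on it.

Measured in a functional assay on CCRF-CEM cells (Homo sapiens) for inhibition, read by MTT assay, with a stated time of 4 days; on this read-out higher numbers stand for weaker inhibition and lower numbers for stronger inhibition:
- Compound 1 `COc1cc(NC(C)CCCNC(=O)NNC(=O)NCCCCCO)c2ncccc2c1`: 170000 nM
- Compound 2 `COc1cc(NC(C)CCCNC(=O)NNC(=O)Nc2ccc(Cl)c(C(F)(F)F)c2)c2ncccc2c1`: 14000 nM
- Compound 3 `COc1cc(NC(C)CCCNC(=O)NNC(=O)NCCO)c2ncccc2c1`: > 250000 nM, a limit and not a number

Compound 3 gives only a limit, > 250000 nM. Compound 4 `COc1cc(NC(C)CCCNC(=O)NNC(=O)NC(CO)(CO)CO)c2ncccc2c1` differs from it on an amide-type nitrogen: 2-hydroxy-1,1-bis(hydroxymethyl)ethyl in place of 2-hydroxyethyl on an amide-type nitrogen. For the measured compounds named here, two measured steps bear on this change. Putting 2-hydroxyethyl in place of 4-chloro-3-(trifluoromethyl)phenyl gave a large step, an at least 17-fold higher number from compound 2 to compound 3 (1.25 log units; beyond the scatter). Between the two hydroxy-bearing chains, the step was small: an at least 1.4-fold higher number from compound 1 to compound 3 (0.16 log units; that floor lies within the scatter). Compound 4 also keeps a hydroxy-bearing group with no ring, so by the small step seen for compound 3, no change beyond the scatter is expected in this assay, and another limit is likely. The expected step is a step that the limit leaves unreadable from compound 3 to compound 4. For compound 4 the estimated value is 300000 nM, with an expected range of 150000 nM to 600000 nM.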

Compound 4, half-maximal inhibitory concentration: > 250000 nM
Compound 4 ended at the assay's limit (the forecaster's own chance of this, stated with the estimate: 70%); the middle value is on the limit's open side.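

In this assay, the large gap to the 4-chloro-3-(trifluoromethyl)phenyl group of compound 2 holds for a second hydroxy-bearing group with no ring on this amide-type nitrogen, with an at least 17-fold higher number from compound 2 to compound 4 (1.25 log units; beyond the scatter). Against 5-hydroxypentyl there is an at least 1.4-fold higher number from compound 1 to compound 4 (0.16 log units; that floor lies within the scatter), so no clear difference is shown. The step between compound 3 and compound 4 cannot be read, because both stop at a limit and not at a number: the limit of > 250000 nM in this assay, at which 2 of the 4 values shown sit.

Still open, from the compounds shown here alone, is whether a plain phenyl, without chlorine or trifluoromethyl, would lower the number as the group of compound 2 does. Going by these compounds, the effect of an amine on the chain also remains unknown.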